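Freeing a Ring Amine Raises Lipoxygenase Inhibition

The source may report more compounds than this note shows. Statements on the series, on what has been measured and on what is new or still open speak of the compounds shown alone.

Compound 1 `CC(C)(C)OC(=O)N1CCN(C(=O)CCCc2cn(Cc3ccccc3)c3ccccc23)CC1`: in an assay on cells for inhibition of Polyunsaturated fatty acid 5-lipoxygenase (Rattus norvegicus), tested at 5 uM (a higher number here means more inhibition at the concentration tested (going by the name of the read-out), a lower number less inhibition), compound 1 gives 38.2%.
Compound 2 `COc1ccc2c(c1)c(CCCC(=O)N1CCN(C(=O)OC(C)(C)C)CC1)c(C)n2Cc1ccccc1`: in this assay compound 2 gives 51.5%.
Compound 3 `O=C(CCCc1cn(Cc2ccccc2)c2ccccc12)N1CCNCC1`: in this assay compound 3 gives 95.4%.

Compound 3 differs from compound 1 in one place, (hydrogen in place of tert-butoxycarbonyl on an amine nitrogen in a ring), and this step raised inhibition by a number 57.2 percentage points higher from compound 1 to compound 3 (beyond the scatter). The same change turns compound 2 into compound 4 `COc1ccc2c(c1)c(CCCC(=O)N1CCNCC1)c(C)n2Cc1ccccc1`, not yet measured: hydrogen in place of tert-butoxycarbonyl on an amine nitrogen in a ring, at the same place in the ring. The difference between the cores of compound 1 and compound 2 is not broken down here; the two values show compound 2 standing higher than compound 1. Compound 4 is expected to gain a number 38.5 percentage points higher from compound 2 to compound 4 (beyond the scatter). This expected step is smaller than a number 57.2 percentage points higher from compound 1 to compound 3 (beyond the scatter) because compound 2 already starts from 51.5%, a higher starting number than compound 1 shows with 38.2%. The estimate for compound 4 in this assay is 90%, between 72% and 99%.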

Compound 4, a percentage reported as inhibition, at one concentration (the size of the read-out at that concentration, not a potency): 64.6%
Estimate against measurement, compound 4: 25.4 percentage points above, outside the stated range (below it).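

Removing the tert-butoxycarbonyl group also raises inhibition on the core of compound 2 in this assay, with a step of a number 13.1 percentage points higher from compound 2 to compound 4 (beyond the scatter). The direction of the change therefore carries over to the second core, but its size does not: the same change on two cores in this assay, a number 57.2 percentage points higher (beyond the scatter) from compound 1 to compound 3 and a number 13.1 percentage points higher (beyond the scatter) from compound 2 to compound 4, 44.1 percentage points apart, beyond the scatter of two such steps. For the compounds shown here, with only two cores, this shows that the gain cannot simply be transferred from one core to another, but it does not show which difference between the cores goes with the smaller step.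

Which part of the core matters remains open. So does how a methyl group on the same ring nitrogen, or a longer chain leading to the amide carbonyl, would compare with the free amine.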